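A few compounds are considered here, and "the series" means these few. Any claim that something is new, unique, unknown or untested is made for them only; others in the source may bear on it.

Compound 3 `COc1cc(N2C(N)=C(C#N)C(c3ccccc3)C3=C2CC(C)(C)CC3=O)cc(OC)c1OC` gives 8% in a functional assay on Ehrlich cells (Mus musculus) for cytotoxicity, tested at 50 ug/mL (a lower number here means a weaker effect, a higher number a stronger effect of the compound at the concentration tested), and stands lowest of the three numbers, though compound 1 `COc1cc(N2C(N)=C(C#N)C(c3c(O)ccc4ccccc34)C3=C2CC(C)(C)CC3=O)cc(OC)c1OC` with 15% lies within the scatter of it, while compound 2 `COc1cc(N2C(N)=C(C#N)C(c3cccc([N+](=O)[O-])c3)C3=C2CC(C)(C)CC3=O)cc(OC)c1OC` with 30% lies beyond. Compound 4 `COc1cc(N2C(N)=C(C#N)C(c3ccc(O)cc3)C3=C2CC(C)(C)CC3=O)cc(OC)c1OC` differs from compound 3 by hydroxy in place of hydrogen on an aromatic carbon. Going by the values given here, no measured step swaps hydrogen for hydroxy; the nearest guide is a number 22 percentage points lower from compound 2 to compound 3 (beyond the scatter), and a number 7 percentage points lower from compound 1 to compound 3 (within the scatter) shows that a ring carrying hydroxy gave no change beyond the scatter. A small step is therefore expected, a number 4 percentage points higher from compound 3 to compound 4 (within the scatter), with no clear direction. Compound 4 is estimated to reach 12%, between 3% and 25%.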

Compound 4, a percentage reported as activity, at one concentration (the size of the read-out at that concentration, not a potency): 90%
For compound 4 the middle estimate is 78 percentage points below the measured one, and the stated range ends below it.
By their numbers in this assay, from the lowest: compounds 3 and 1 (each within the scatter of the next); then compound 2; then compound 4.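

In this assay, the change from phenyl to 4-hydroxyphenyl gives a number 82 percentage points higher from compound 3 to compound 4 (beyond the scatter), so this single aromatic carbon can carry a very large change. The 4-hydroxyphenyl group also stands clear of the other aryl groups, with a number 60 percentage points higher from compound 2 to compound 4 (beyond the scatter) and a number 75 percentage points higher from compound 1 to compound 4 (beyond the scatter), which shows that a hydroxy-bearing ring alone does not guarantee the effect, since the 2-hydroxynaphthalen-1-yl group of compound 1 carries hydroxy too. No available evidence accounts for this rise. The compounds shown leave open whether an amine or a methoxy group at this same carbon would keep the effect.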